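Indole replacements on the piperidine carbon of the core

The source may hold more compounds than are shown below. What is called first, only, known or untested is meant among the compounds shown, and "the series" means these compounds.

Three compounds of this series have numbers in an assay on isolated protein for inhibition of cathepsin S (Homo sapiens); a lower number here means a stronger inhibitor, a higher number a weaker inhibitor. Compound 1 `CS(=O)(=O)N1CCc2c(c(-c3ccc(C(F)(F)F)cc3)nn2CC(O)CN2CCC(c3csc4cc(F)ccc34)CC2)C1` gives 180 nM. Compound 2 `COc1ccc2[nH]cc(C3CCN(CC(O)Cn4nc(-c5ccc(C(F)(F)F)cc5)c5c4CCN(S(C)(=O)=O)C5)CC3)c2c1` gives 29 nM, and compound 3 `CCOC(=O)c1ccc2[nH]cc(C3CCN(CC(O)Cn4nc(-c5ccc(C(F)(F)F)cc5)c5c4CCN(S(C)(=O)=O)C5)CC3)c2c1` gives 27 nM. Compound 2 thus holds the second highest of the three numbers: compound 3 sits within the scatter of it, while compound 1 lies beyond the scatter on the higher side. The step of a 6.2-fold lower number from compound 1 to compound 2 (0.79 log units; beyond the scatter) shows that the bicyclic group on the saturated ring carbon matters; the step of a 1.1-fold lower number from compound 2 to compound 3 (0.03 log units; within the scatter) shows that a change of the substituent on the indole benzene ring leaves the number essentially unchanged.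

Compound 4 `CS(=O)(=O)N1CCc2c(c(-c3ccc(C(F)(F)F)cc3)nn2CC(O)CN2CCC(c3c[nH]c4cc(Cl)ccc34)CC2)C1` differs from compound 2 in one place: 6-chloro-1H-indol-3-yl in place of 5-methoxy-1H-indol-3-yl on a saturated ring carbon. The indole with its hydrogen-bond donor is kept, so the change resembles the step from compound 2 to compound 3 more than the step from compound 1 to compound 2, although here the acceptor is lost and the substituent position differs. No step beyond the scatter is therefore expected in this assay for compound 4. The expected step is a 1.2-fold higher number from compound 2 to compound 4 (0.08 log units; within the scatter). For compound 4 the estimate in this assay is 35 nM, with a range from 12 nM to 110 nM.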

Compound 4, half-maximal inhibitory concentration: 29 nM
For compound 4 the middle estimate is 1.2-fold (0.08 log units) above the measured one, and the stated range covers the measured number.
By their numbers in this assay, from the lowest: compounds 3, 2 and 4 (each within the scatter of the next); then compound 1.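

In this assay, the change at this saturated ring carbon gives no change at the digits printed from compound 2 to compound 4 (within the scatter), so across these two indoles neither the loss of the hydrogen-bond acceptor nor the swap of methoxy for chlorine on a different named position of the indole moves the number beyond the scatter. The gain over the benzothiophene also appears with a second indole, as a 6.2-fold lower number from compound 1 to compound 4 (0.79 log units; beyond the scatter), so it is not confined to the 5-methoxy-1H-indol-3-yl group, although this pair differs in both the ring hetero atom and the halogen, and the two changes cannot be separated here. No measurement is available that explains why these indoles behave alike or why they differ from the benzothiophene.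

Open, from the compounds shown here alone, is how much of that gain belongs to the indole ring itself and how much to the halogen, a question that 6-chloro-1-benzothiophen-3-yl or 6-fluoro-1H-indol-3-yl would address directly. Also open, going by these compounds, is whether the flat response to substituents on the indole benzene ring extends to an amine, a carboxylic acid or an unsubstituted 1H-indol-3-yl group.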